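The source may hold more compounds than are shown below. What is called first, only, known or untested is meant among the compounds shown, and "the series" means these compounds.

Compound 1 `O=C(/C=C/c1ccc2c(c1)B(O)OC2)c1ccc(Cl)cc1`, compound 2 `O=C(/C=C/c1ccc2c(c1)B(O)OC2)c1ccc(Br)cc1` and compound 3 `O=C(/C=C/c1ccc2c(c1)B(O)OC2)c1ccc(I)cc1` share one core and differ only in the halogen on the aromatic ring attached to the carbonyl carbon. In a toxicity assay on MCF-10A cells (Homo sapiens) for cytotoxicity, read by MTT assay, with a stated time of 48 h (a higher number here means a weaker inhibitor, a lower number a stronger inhibitor), compound 1 gives 12100 nM, and compound 2 gives 27800 nM. For compound 3 the assay reports only a limit, > 100000 nM; this is the limit recorded as the limit of > 100000 nM in this assay, at which 1 of the 3 values shown sits. Compound 3 therefore stands at the top of the numbers known, without an exact value: the step of an at least 8.2-fold higher number from compound 1 to compound 3 (0.91 log units; beyond the scatter) and the step of an at least 3.5-fold higher number from compound 2 to compound 3 (0.55 log units; beyond the scatter) are known only as minima, while the step of a 2.3-fold higher number from compound 1 to compound 2 (0.36 log units; beyond the scatter) is a measured modest rise.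

Compound 4 `Cc1cccc(C(=O)/C=C/c2ccc3c(c2)B(O)OC3)c1` is not yet measured. It differs from compound 3 by 3-methylphenyl in place of 4-iodophenyl on a carbonyl carbon. For the measured compounds named here, none of the measured steps covers this change: each exchanged one halogen for another, and none introduced a methyl. What the three halogen compounds do show is a falling number from iodo through bromo to chloro, so a departure from the 4-iodophenyl group may be expected to carry compound 4 back below the limit. The writer expects a step of an at least 4.0-fold lower number from compound 3 to compound 4 (0.60 log units; beyond the scatter) toward a lower number, with wide uncertainty. For compound 4 the estimated value in this assay is 25000 nM, between 8000 nM and 100000 nM.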

Compound 4, half-maximal inhibitory concentration: 15900 nM
The estimate for compound 4 lay 1.6-fold (0.20 log units) above the measured number, and the stated range covers the measured number.
By their numbers in this assay, from the lowest: compounds 1, 4 and 2 (each within the scatter of the next, the first and the last beyond it). At a limit, above all of these: compound 3.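

In this assay, 3-methylphenyl in place of 4-iodophenyl on the carbonyl carbon returns the series to a measured number, an at least 6.2-fold lower number from compound 3 to compound 4 (0.79 log units; beyond the scatter), which shows that the high reading of compound 3 does not extend to every change at this position. A group with no halogen also lands among the chloro and bromo compounds, with a 1.7-fold lower number from compound 2 to compound 4 (0.24 log units; within the scatter) and a 1.3-fold higher number from compound 1 to compound 4 (0.12 log units; within the scatter), so the numbers do not separate 3-methylphenyl from 4-bromophenyl or 4-chlorophenyl. The step from compound 3 is a minimum, and compound 3 has only a limit, not an exact number: the limit of > 100000 nM in this assay, at which 1 of the 4 values shown sits.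

The substituent and its place on the ring changed together between compound 3 and compound 4, so the compounds shown cannot tell how much of the step belongs to losing the iodine and how much to the different place of the new group. They also leave open how an amine or a carboxylic acid in place of the methyl would read in this assay.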